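Swapping the Aryl Group on the Chain for 4-Chlorophenyl

This account rests on a few compounds, and the source may have more. Where it says the series, first, only, none or still open, it means among the compounds named here.

Of the compounds shown here, three sharing one core have been measured in an ADME assay on the whole organism for cytotoxicity, with Artemia salina as the target, with a stated time of 24 h; on this read-out higher numbers stand for an effect only at larger amounts of compound and lower numbers for an effect already at smaller amounts. Compound 1 `Cc1ccc(S(=O)(=O)NC(=O)Nc2ccccc2C(=O)/C=C/c2ccc(N(C)C)cc2)cc1` gives 38.1 ug/mL in this assay. Compound 2 `COc1ccc(/C=C/C(=O)c2ccccc2NC(=O)NS(=O)(=O)c2ccc(C)cc2)c(OC)c1` gives 16 ug/mL, and compound 3 `CCc1cc(/C=C/C(=O)c2ccccc2NC(=O)NS(=O)(=O)c2ccc(C)cc2)cc(OC)c1OC` gives 19.2 ug/mL. Compound 3 holds the second highest of the three numbers, yet its steps to both other compounds lie within the scatter: a 1.2-fold higher number from compound 2 to compound 3 (0.08 log units; within the scatter) and a 2.0-fold lower number from compound 1 to compound 3 (0.30 log units; within the scatter). Among the measured compounds shown here, the only step beyond the scatter is a 2.4-fold lower number from compound 1 to compound 2 (0.38 log units; beyond the scatter), a modest one.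

Compound 4 `Cc1ccc(S(=O)(=O)NC(=O)Nc2ccccc2C(=O)/C=C/c2ccc(Cl)cc2)cc1` differs from compound 3 in one place: 4-chlorophenyl in place of 3-ethyl-4,5-dimethoxyphenyl on a double-bonded chain carbon bound to a double-bonded chain carbon

All three measured steps change the group at this same place, and none of them exceeds a modest size, so the group bound to the double-bonded chain carbon has so far moved this assay little. For the measured compounds named here, no measured compound carries a 4-chlorophenyl, so the expectation rests on that pattern alone. A small step, if any, is expected, roughly a 1.1-fold higher number from compound 3 to compound 4 (0.06 log units; within the scatter) in this assay. Compound 4 is therefore estimated at 22 ug/mL in this assay, within a range of 9 ug/mL to 55 ug/mL.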

Compound 4, concentration for half-maximal effect: 6.92 ug/mL
For compound 4 the middle estimate is 3.2-fold (0.50 log units) above the measured one; the whole stated range lies above it.
By their numbers in this assay, from the lowest: compound 4; then compounds 2, 3 and 1 (each within the scatter of the next, the first and the last beyond it).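

Among the compounds shown here, the position is not as indifferent in this assay as the earlier compounds suggested: with 4-chlorophenyl on the double-bonded chain carbon, compound 4 stands apart from all three others, each step lying beyond the scatter (a 2.8-fold lower number from compound 3 to compound 4 (0.44 log units; beyond the scatter); a 2.3-fold lower number from compound 2 to compound 4 (0.36 log units; beyond the scatter); a 5.5-fold lower number from compound 1 to compound 4 (0.74 log units; beyond the scatter)). Among the earlier compounds, only the step from compound 1 to compound 2 went beyond the scatter, so this is the first group at this place to separate from every other one, although each step remains modest. Nothing available here accounts for the shift.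

The compounds shown leave open whether chlorine itself matters or whether the same low number would come with a plain phenyl, 4-fluorophenyl or 4-bromophenyl. They also do not show whether a 3-chlorophenyl would behave like the 4-chlorophenyl.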